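Pyrazolopyrimidine chalcones: para-methyl removal in compound 4

The compounds below may be only part of what the source reports. "The series", "measured", "known", "first", "only" and "open" are said of these compounds alone.

Measured so far:
compound 1 `COc1ccc(C(=O)/C=C/c2cc(-c3ccc(OC)c(OC)c3)n3nc(-c4ccccc4)cc3n2)cc1` gives 14600 nM
compound 2 `COc1cc(-c2cc(C(=O)/C=C/c3ccc(C)cc3)nc3cc(-c4ccccc4)nn23)cc(OC)c1OC` gives 21900 nM
compound 3 `COc1ccc(-c2cc(C(=O)/C=C/c3ccc(C)cc3)nc3cc(-c4ccccc4)nn23)cc1OC` gives 19500 nM

All three numbers come from a functional assay on DU-145 cells (Homo sapiens) for antiproliferative activity, read by MTT assay, with a stated time of 24 h; on this read-out higher numbers stand for weaker inhibition and lower numbers for stronger inhibition. Compound 2 sits alongside compound 3 and compound 1: both of its gaps to them lie within the scatter, so the three compounds cannot be told apart on these figures.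

Compound 4 `COc1cc(-c2cc(C(=O)/C=C/c3ccccc3)nc3cc(-c4ccccc4)nn23)cc(OC)c1OC` is not yet measured. The change from compound 2 to compound 4 is hydrogen in place of methyl on an aromatic carbon.

Among the measured compounds shown here, two measured steps bear on it, neither closely. The step of a 1.1-fold lower number from compound 2 to compound 3 (0.05 log units; within the scatter) removes a methoxy from an aromatic carbon of the shared core and leaves the number unchanged beyond the scatter. The step of a 1.3-fold higher number from compound 1 to compound 3 (0.13 log units; within the scatter) swaps the whole side chain and likewise stays within the scatter. Nothing in this set shows a single small substituent on a phenyl ring moving the read-out, and the change to compound 4 is smaller than either measured step. The expectation for a 1.0-fold lower number from compound 2 to compound 4 (0.02 log units; within the scatter) is therefore a step within the scatter, in no particular direction.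

Compound 4 is estimated at 21000 nM, with a range from 9000 nM to 48000 nM.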

Compound 4, half-maximal inhibitory concentration: 16300 nM
Estimate against measurement, compound 4: 1.3-fold (0.11 log units) above, and the stated range covers the measured number.
By their numbers in this assay, from the lowest: compounds 1, 4, 3 and 2 (each within the scatter of the next).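

Taking the methyl off the side chain, 4-methylphenyl to phenyl, gives the first direct reading at this place, para to a large group: in this assay the step reads a 1.3-fold lower number from compound 2 to compound 4 (0.13 log units; within the scatter) and does not separate the two compounds. Methyl and hydrogen at this position therefore cannot be told apart on these figures, just as the methoxy change on the shared core in a 1.1-fold lower number from compound 2 to compound 3 (0.05 log units; within the scatter) could not be read as a real difference. No measurement beyond the read-out itself bears on this result.

With only methyl and hydrogen shown at this position, it remains open whether a group of another kind there, such as an amine, a carboxylic acid or a longer chain, would move the number in this assay beyond the scatter. From the compounds shown here alone, it also remains open whether any change to this side chain would separate compounds at all, since the four numbers so far form a run in which each lies within the scatter of the next.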